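The compounds below may be only part of what the source reports. "The series", "measured", "known", "first", "only" and "open" are said of these compounds alone.

Three compounds measured in a functional assay on U-373MG ATCC cells (Homo sapiens) for inhibition, read by MTT assay, with a stated time of 72 h (a higher number here means a weaker inhibitor, a lower number a stronger inhibitor), share a bicyclic core carrying a urea or thiourea. Compound 1 `CC1(C)CC(NC(=S)NCc2ccccc2)c2cc(Br)ccc2O1` gives 29000 nM. Compound 2 `CC1(C)CC(NC(=O)Nc2ccc(Cl)cc2)c2cc(Cl)ccc2O1` gives 19000 nM, and compound 3 `CC1(C)CC(NC(=O)Nc2ccc(Cl)cc2)c2cc(Br)ccc2O1` gives 25000 nM. Between compound 3 and compound 2 the only change is chloro in place of bromo on an aromatic carbon, and the step is a 1.3-fold lower number from compound 3 to compound 2 (0.12 log units; within the scatter). How the core of compound 1 differs from that of compound 3 is not broken down here.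

Compound 4 `CC1(C)CC(NC(=S)NCc2ccccc2)c2cc(Cl)ccc2O1` is not yet measured. It arises from compound 1 by chloro in place of bromo on an aromatic carbon, the same change seen between compound 3 and compound 2. Because a 1.3-fold lower number from compound 3 to compound 2 (0.12 log units; within the scatter) was within the scatter, the expected step is a 1.3-fold lower number from compound 1 to compound 4 (0.10 log units; within the scatter). The estimate for compound 4 is 23000 nM, expected to fall between 12000 nM and 45000 nM.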

Compound 4, half-maximal inhibitory concentration: 64000 nM
Compound 4: the middle estimate sits 2.8-fold (0.44 log units) below what was measured, outside the stated range (above it).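

In this assay, chloro in place of bromo on an aromatic carbon gives a 2.2-fold higher number from compound 1 to compound 4 (0.34 log units; beyond the scatter). The same change therefore does not carry over from one core to the other with a fixed size or direction: the same change on two cores in this assay, a 1.3-fold lower number (0.12 log units; within the scatter) from compound 3 to compound 2 and a 2.2-fold higher number (0.34 log units; beyond the scatter) from compound 1 to compound 4, 2.9-fold (0.46 log units) apart, beyond the scatter of two such steps This rests on just two pairs of compounds, so it shows that the outcome of the swap can depend on the core, but it does not show which feature of the cores is responsible or how often such a split would occur in this series.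

Which of the two steps the swap would resemble on further cores remains open. Also open, as far as these compounds go, is how a fluoro, a methyl or an amine in the same place would affect the number.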